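Adding a carboxy-bearing group to the amino nitrogen of compound 2

A few compounds are considered here, and "the series" means these few. Any claim that something is new, unique, unknown or untested is made for them only; others in the source may bear on it.

Compound 1 `COc1ccc(NS(=O)(=O)/C=C/c2c(OC)cc(OC)cc2OC)cc1`: 100 nM
Compound 2 `COc1cc(OC)c(/C=C/S(=O)(=O)Nc2ccc(OC)c(N)c2)c(OC)c1`: 8 nM

Both values come from a functional assay on LNCaP cells (Homo sapiens) for cytotoxicity, read by trypan blue exclusion, with a stated time of 96 h; a lower number here means a stronger inhibitor of growth, a higher number a weaker inhibitor of growth. Of the two, compound 2 has the lower number, at 8 nM. Among the compounds with values here, the only measured step is a 13-fold lower number from compound 1 to compound 2 (1.10 log units; beyond the scatter). This large step came with amino in place of hydrogen on an aromatic carbon.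

The next compound is compound 3 `COc1cc(OC)c(/C=C/S(=O)(=O)Nc2ccc(OC)c(NC(C)(C)C(=O)O)c2)c(OC)c1`. Its difference from compound 2 is 1-carboxy-1-methylethyl in place of hydrogen on a nitrogen on an aromatic ring. Here 1-carboxy-1-methylethyl takes the place of hydrogen on a nitrogen on an aromatic ring, so amino becomes (1-carboxy-1-methylethyl)amino.

The measured step bears on this change only indirectly. Within the data shown here, it shows that the number moved sharply when the amino group appeared, but no measured compound carries anything on that nitrogen. Given a 13-fold lower number from compound 1 to compound 2 (1.10 log units; beyond the scatter), part of that gain could be lost once the amino group is altered. The expected change is therefore moderate and toward a weaker inhibitor of growth, an estimated 3.8-fold higher number from compound 2 to compound 3 (0.57 log units; beyond the scatter). For compound 3 the estimated value in this assay is 30 nM, within a range of 8 nM to 120 nM.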

Compound 3, concentration for 50% growth inhibition: 100 nM
The estimate for compound 3 lay 3.3-fold (0.52 log units) below the measured number; the range from low to high includes it.
By their numbers in this assay, from the lowest: compound 2; then compounds 1 and 3 (each within the scatter of the next).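

In this assay, the amino nitrogen of compound 2 did not tolerate this substitution: placing 1-carboxy-1-methylethyl on it gave a 13-fold higher number from compound 2 to compound 3 (1.10 log units; beyond the scatter). Measured against hydrogen on the aromatic carbon, the whole (1-carboxy-1-methylethyl)amino group gave no change at the digits printed from compound 1 to compound 3 (within the scatter), so the gain that came with the plain amino group was not retained once this group stood on the nitrogen. Nothing available here accounts for this loss.

The compounds shown leave open which part of the 1-carboxy-1-methylethyl group goes with the loss, the carboxylic acid or the carbon bearing the two methyl groups; a methyl ester in place of the acid, or a carboxymethyl or isopropyl group on the same nitrogen, would help to separate the two. They also leave open whether a smaller group on that nitrogen, such as a single methyl or an acetyl, would keep the low number of compound 2 or would bring a similar loss.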